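The compounds below may be only part of what the source reports. "The series", "measured", "known", "first", "only" and "open" are said of these compounds alone.

Of the compounds shown here, three have been measured in a functional assay on NCI-H460 cells (Homo sapiens) for antiproliferative activity, read by sulforhodamine B assay, with a stated time of 48 h; a higher number here means a weaker inhibitor, a lower number a stronger inhibitor. Compound 1 `O=C(CCCCCCN1C(=O)/C(=N\O)c2cc(Cl)ccc21)NO` gives 850 nM in this assay. Compound 2 `O=C(CCCCCCN1C(=O)/C(=N\O)c2cc(Br)ccc21)NO` gives 970 nM in this assay. Compound 3 `CO/N=C1/C(=O)N(CCCCCCC(=O)NO)c2ccc(Cl)cc21` gives 760 nM in this assay; among the three measured compounds it has the lowest number, but its gaps to compound 1 and compound 2 are both within the scatter, so nothing can be said about an order among them.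

Compound 1 and compound 2 differ in one place, the change being (bromo in place of chloro on an aromatic carbon). That change made a step of a 1.1-fold higher number from compound 1 to compound 2 (0.06 log units; within the scatter), which is within the scatter: swapping one halogen for the other left the number essentially where it was.

Compound 4 `CO/N=C1/C(=O)N(CCCCCCC(=O)NO)c2ccc(Br)cc21` has not been measured yet. It is related to compound 3 by bromo in place of chloro on an aromatic carbon, the same change that turns compound 1 into compound 2, and at the same place. The cores of compound 3 and compound 1 differ in a way that is not broken down here.

Among the measured compounds shown here, since the one earlier example of this change, from compound 1 to compound 2, stayed within the scatter, the step from compound 3 to compound 4 is expected to be similar, around a 1.1-fold higher number from compound 3 to compound 4 (0.06 log units; within the scatter) in this assay. On that basis compound 4 is estimated to give about 870 nM in this assay, most likely between 500 nM and 1500 nM.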

Compound 4, half-maximal inhibitory concentration: 2900 nM
Compound 4: the middle estimate sits 3.3-fold (0.52 log units) below what was measured; measured number above the stated range.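

In this assay, putting bromo in place of chloro on the aromatic carbon gave a clear loss of activity on the core of compound 3, a step of a 3.8-fold higher number from compound 3 to compound 4 (0.58 log units; beyond the scatter) in which a higher number means a weaker inhibitor. The same change on the two cores therefore did not give the same result: the same change on two cores in this assay, a 1.1-fold higher number (0.06 log units; within the scatter) from compound 1 to compound 2 and a 3.8-fold higher number (0.58 log units; beyond the scatter) from compound 3 to compound 4, 3.3-fold (0.52 log units) apart, beyond the scatter of two such steps. This shows that, within this small series, a halogen swap that made no readable difference on one core cannot simply be assumed to do the same on a closely related core, but it does not explain why the cores respond differently, and two pairs of compounds give no general rule for any other core.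

The compounds shown leave open whether this difference between the cores is specific to bromo or would also appear with another group at the same place, such as fluoro, methyl or methoxy. They also leave open whether the difference would persist with a longer chain carrying the hydroxamic acid, and how either core would respond in a different cell line.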